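Ring amide terminus: cyclobutyl replacing dihydroxypropyl

A few compounds are considered here, and "the series" means these few. Any claim that something is new, unique, unknown or untested is made for them only; others in the source may bear on it.

Measured compounds in an assay for inhibition of RAC-alpha serine/threonine-protein kinase (Homo sapiens), read by HTRF, with a stated time of 1 h; on this read-out higher numbers stand for weaker inhibition and lower numbers for stronger inhibition:
compound 1 `Cn1ncc(Cl)c1-c1cc(C(=O)N[C@@H]2CN[C@H](CC(=O)NC3CC3)C[C@H]2c2ccc(Cl)c(Cl)c2)oc1Cl` gives 3.95 nM
compound 2 `Cn1ncc(Cl)c1-c1cc(C(=O)N[C@@H]2CN[C@H](CCN3CCC(O)CC3)C[C@H]2c2ccc(Cl)c(Cl)c2)oc1Cl` gives 5.99 nM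
compound 3 `Cn1ncc(Cl)c1-c1cc(C(=O)N[C@@H]2CN[C@H](CC(=O)NCC(O)CO)C[C@H]2c2ccc(Cl)c(Cl)c2)oc1Cl` gives 3.13 nM

Compound 3 carries the lowest number of the three, yet its steps to compound 1 and compound 2 both fall within the scatter, so no order among them is claimed. Compound 4 `Cn1ncc(Cl)c1-c1cc(C(=O)N[C@@H]2CN[C@H](CC(=O)NC3CCC3)C[C@H]2c2ccc(Cl)c(Cl)c2)oc1Cl` differs from compound 3 by cyclobutyl in place of 2,3-dihydroxypropyl on an amide-type nitrogen. Within the data shown here, the only measured step on that same nitrogen is a 1.3-fold lower number from compound 1 to compound 3 (0.10 log units; within the scatter), a change within the scatter; the other steps, a 1.5-fold higher number from compound 1 to compound 2 (0.18 log units; within the scatter) and a 1.9-fold lower number from compound 2 to compound 3 (0.28 log units; within the scatter), likewise stayed within the scatter. Cyclobutyl is close in kind to the cyclopropyl of compound 1. Because a 1.3-fold lower number from compound 1 to compound 3 (0.10 log units; within the scatter) stayed within the scatter, compound 4 in this assay is expected to show a 1.3-fold higher number from compound 3 to compound 4 (0.11 log units; within the scatter). Compound 4 is therefore estimated at 4 nM, with a range from 1.8 nM to 9 nM.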

Compound 4, half-maximal inhibitory concentration: 7.98 nM
Estimate against measurement, compound 4: 2.0-fold (0.30 log units) below, and the stated range covers the measured number.
By their numbers in this assay, from the lowest: compounds 3, 1, 2 and 4 (each within the scatter of the next, the first and the last beyond it).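

In this assay, among these compounds, the amide-type nitrogen gives the first steps beyond the scatter, both modest: a 2.5-fold higher number from compound 3 to compound 4 (0.41 log units; beyond the scatter) and a 2.0-fold higher number from compound 1 to compound 4 (0.31 log units; beyond the scatter). Cyclobutyl therefore separates from both 2,3-dihydroxypropyl and cyclopropyl, although those two groups stayed within the scatter of each other. Against the (4-hydroxypiperidin-1-yl)methyl side chain, the change to cyclobutylcarbamoyl gives a 1.3-fold higher number from compound 2 to compound 4 (0.12 log units; within the scatter), also within the scatter. No evidence here accounts for these steps.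

Open, from the compounds shown here alone, is whether cyclopentyl on this nitrogen would extend the cyclopropyl to cyclobutyl step. Also open, going by these compounds, is how a chain ending in a primary amine or a carboxylic acid would read here.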